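Swapping a pyridinylmethyl for a fluorophenyl on the piperazine

A few compounds are considered here, and "the series" means these few. Any claim that something is new, unique, unknown or untested is made for them only; others in the source may bear on it.

Measured so far:
- compound 1, `Nc1ccccc1NC(=O)c1ccc(CSC(=S)N2CCN(Cc3ccccn3)CC2)cc1`: in a functional assay on HeLa cells (Homo sapiens) for antiproliferative activity, read by CCK-8 assay, with a stated time of 72 h, tested at 8 uM (on this read-out higher numbers stand for a stronger effect at the one concentration tested and lower numbers for a weaker effect), compound 1 gives 61.4%
- compound 2, `CC1CCCCN1C(=S)SCc1ccc(C(=O)Nc2ccccc2N)cc1`: in this assay compound 2 gives 76.3%
- compound 3, `CN(Cc1ccncc1)C(=S)SCc1ccc(C(=O)Nc2ccccc2N)cc1`: in this assay compound 3 gives 72.7%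

All three share the same core, a benzamide bearing an aminophenyl group, joined through a sulfur to a thiocarbonyl that carries an amine. Compound 1 sits lowest of the three, and both compound 2 and compound 3 lie above it by more than the usual scatter. For the measured compounds named here, the only step between compounds differing in a single place is a number 3.6 percentage points lower from compound 2 to compound 3 (within the scatter), and it concerns the group on the thiocarbonyl carbon, not the ring nitrogen.

Compound 4, `Nc1ccccc1NC(=O)c1ccc(CSC(=S)N2CCN(c3ccc(F)cc3)CC2)cc1`, differs from compound 1 in one place: 4-fluorophenyl in place of (pyridin-2-yl)methyl on an amine nitrogen in a ring. Going by the values given here, no measured step touches this position, so nothing here says whether the exchange should raise or lower the number in this assay. The expectation is therefore a change no larger than the scatter, with compound 4 estimated at 64% (range 45% to 83%), an expected step of a number 2.6 percentage points higher from compound 1 to compound 4 (within the scatter).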

Compound 4, a percentage reported as inhibition, at one concentration (the size of the read-out at that concentration, not a potency): 64.5%
Beside the measured number, compound 4's estimate is 0.5 percentage points below it, within the range that was stated.
By their numbers in this assay, from the lowest: compounds 1, 4, 3 and 2 (each within the scatter of the next, the first and the last beyond it).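

At this position on the piperazine, the first measured exchange gives a number 3.1 percentage points higher from compound 1 to compound 4 (within the scatter) in this assay, so a (pyridin-2-yl)methyl and a 4-fluorophenyl cannot be told apart on this read-out. The two groups have the same number of heavy atoms but differ in their make-up: the entering ring is of carbon only and carries fluorine, whereas the leaving ring holds a nitrogen and is attached through a carbon link. Nothing available explains the result.

On these data alone, this single exchange alters the link, the ring atoms and the fluorine together, so the contribution of each remains unknown. A plain phenyl, a benzyl or a 4-fluorobenzyl on this nitrogen could separate them, while a carboxylic acid on a short chain would test a very different kind of group.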